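From Acid Back to Carbamoyl, Two Carbons Further Out

The compounds below may be only part of what the source reports. "The series", "measured", "known", "first", "only" and "open" are said of these compounds alone.

Among the compounds with values here, compound 2 `O=C(O)C1CCN(c2nc(-c3cc(F)c(Cl)cc3F)nc3c2CS(=O)(=O)C3)CC1` gives 560 nM in a functional assay on HEK293 cells for agonist activity at Glucose-dependent insulinotropic receptor (Homo sapiens), read by reporter gene assay and cAMP accumulation, with a stated time of 6 h (a higher number here means that more compound is needed for the effect, a lower number that less compound is needed), the highest of the two numbers measured so far. Compound 1 `NC(=O)C1CCN(c2nc(-c3cc(F)c(Cl)cc3F)nc3c2CS(=O)(=O)C3)CC1` gives 21 nM, and the step of a 27-fold higher number from compound 1 to compound 2 (1.43 log units; beyond the scatter) shows what the carboxy group cost. Compound 3 `NC(=O)CCC1CCN(c2nc(-c3cc(F)c(Cl)cc3F)nc3c2CS(=O)(=O)C3)CC1` carries 2-carbamoylethyl in place of carboxy on a saturated ring carbon. A carbamoyl group thus returns, now at the end of a short chain, so the step from compound 1 to compound 2 is the one that bears on it and is expected to reverse in part. Compound 3 is estimated at 60 nM, within 15 nM to 250 nM, a step of a 9.3-fold lower number from compound 2 to compound 3 (0.97 log units; beyond the scatter).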

Compound 3, effective concentration (reported as EC, without a stated level of effect): 18 nM
Compound 3: the middle estimate sits 3.3-fold (0.52 log units) above what was measured, and the stated range covers the measured number.
By their numbers in this assay, from the lowest: compounds 3 and 1 (each within the scatter of the next); then compound 2.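

With a 1.2-fold lower number from compound 1 to compound 3 (0.07 log units; within the scatter) the carbamoyl group keeps its effect in this assay when it sits at the end of a short chain on this saturated ring carbon, not only directly on the ring. With a 31-fold lower number from compound 2 to compound 3 (1.49 log units; beyond the scatter) the chain amide also regains everything lost with the carboxy group, not just part of it. Nothing available here explains the size of these steps. Still open, going by these compounds, is whether a carboxylic acid at the end of the same chain would fare as poorly as carboxy on the ring. On these data alone, a shorter or longer chain, or an amine at its end, also remains untested in these compounds.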